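The compounds below may be only part of what the source reports. "The series", "measured", "known", "first", "only" and "open" are said of these compounds alone.

Compound 3 `CCOC(=O)C1(Cc2ccccc2)CN(c2ccccc2)Cc2nnn(Cc3ccccc3Cl)c21` is the starting point of this step. In an ADME assay on HEL cells (Homo sapiens) for cytotoxicity, read by microscopy, with a stated time of 3 days (on this read-out lower numbers stand for higher toxicity in this test and higher numbers for lower toxicity in this test), compound 3 reaches only a limit, > 100000 nM, so no number stands for it. Compound 1 `CCOC(=O)C1(Cc2ccccc2)CN(c2ccccc2)Cc2nnn(Cc3ccccc3)c21` also ends at a limit in this assay, >= 20000 nM. Compound 2 `CCOC(=O)C1(Cc2ccccc2)CN(c2ccccc2)Cc2nnn(Cc3cc(OC)c(OC)c(OC)c3)c21` ends at a limit too, >= 100000 nM. All three measured values are limits rather than numbers, as the limit of > 100000 nM in this assay, at which 1 of the 3 values shown sits, the limit of >= 100000 nM in this assay, at which 1 of the 3 values shown sits, and the limit of >= 20000 nM in this assay, at which 1 of the 3 values shown sits, record, so compound 3 cannot be placed against the other two beyond saying that it sits at a limit. The change leading to compound 4 `CCCCCCCCn1nnc2c1C(Cc1ccccc1)(C(=O)OCC)CN(c1ccccc1)C2` is heptyl in place of 2-chlorophenyl on a saturated chain carbon bound to an aromatic nitrogen. The measured steps at the same place are a step that the two limits leave unreadable from compound 1 to compound 2 and a step that the two limits leave unreadable from compound 2 to compound 3, and the remaining one is a step that the two limits leave unreadable from compound 1 to compound 3; none of them can be sized. The expected step is therefore a number no higher from compound 3 to compound 4 (the limit leaves the size open), with nothing beyond the scatter foreseen. Compound 4 is estimated at 100000 nM in this assay. Compound 4 is expected to lie between 20000 nM and 200000 nM, most probably again as a limit.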

Compound 4, minimum cytotoxic concentration: >= 20000 nM
Compound 4 was reported as a limit; the forecaster's own chance of this, stated with the estimate: 80%; the middle value is on the limit's open side.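

In this assay compound 4 also ends at a limit, >= 20000 nM. Within the data shown here, compound 1, compound 2 and compound 3 stand at limits too, so no step from any of them to compound 4 can be read. The compounds shown leave open how strongly any substituent at this place changes the minimum cytotoxic concentration.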